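Replacing the boron-bearing group of compound 2 with phenyl

The source may hold more compounds than are shown below. What is called first, only, known or untested is meant among the compounds shown, and "the series" means these compounds.

Measured in a functional assay on MDA-MB-231 cells (Homo sapiens) for antiproliferative activity, read by MTT assay, with a stated time of 72 h; on this read-out higher numbers stand for weaker inhibition and lower numbers for stronger inhibition:
- compound 1 `COc1cccc(-c2cccc(NC(=O)CCc3ccc4c(c3)COB4O)c2)c1`: 90000 nM
- compound 2 `COc1cc(OC)cc(-c2cccc(NC(=O)CCc3ccc4c(c3)COB4O)c2)c1`: 77000 nM
- compound 3 `CC(=O)c1ccc(-c2cccc(NC(=O)CCc3ccc4c(c3)COB4O)c2)cc1`: 66000 nM

The three values form a flat set. Compound 2, at 77000 nM, cannot be separated from its two neighbours, with a 1.2-fold lower number from compound 1 to compound 2 (0.07 log units; within the scatter) and a 1.2-fold lower number from compound 2 to compound 3 (0.07 log units; within the scatter). The widest measured step is a 1.4-fold lower number from compound 1 to compound 3 (0.13 log units; within the scatter).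

Compound 4 `COc1cc(OC)cc(-c2cccc(NC(=O)CCc3ccccc3)c2)c1` departs from compound 2 at a different place: a group of 6 heavy atoms (6 carbon; one six-membered aromatic ring of carbon only) in place of a group of 10 heavy atoms (7 carbon, 1 boron, 2 oxygen; one five-membered non-aromatic ring with 2 hetero atoms, one six-membered aromatic ring of carbon only), on a saturated chain carbon, two bonds along the chain from a carbonyl carbon. The group that leaves carries the boron found in all three measured compounds.

All three measured steps alter only the methoxyphenyl or acetylphenyl group, so none of them sizes this replacement. For the measured compounds named here, they show only that changes elsewhere left this assay flat. The data therefore support no firm direction, and a wide range is needed around a figure close to compound 2. The expected change is a 1.2-fold higher number from compound 2 to compound 4 (0.07 log units; within the scatter). For compound 4 the estimated value is 90000 nM, with an expected range of 35000 nM to 250000 nM.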

Compound 4, half-maximal inhibitory concentration: 87000 nM
For compound 4 the middle estimate is 1.0-fold (0.01 log units) above the measured one, and the stated range covers the measured number.
By their numbers in this assay, from the lowest: compounds 3, 2, 4 and 1 (each within the scatter of the next).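

On a saturated chain carbon, two bonds along the chain from a carbonyl carbon, phenyl in place of the boron-bearing group gives, in this assay, a 1.1-fold higher number from compound 2 to compound 4 (0.05 log units; within the scatter). The earlier steps shown here touched only the methoxyphenyl or acetylphenyl group, whereas this one shows that the series stays flat even when the boron, the five-membered ring with its 2 hetero atoms, the hydrogen-bond donor and both hydrogen-bond acceptors all leave together. No measurement offered here accounts for this result.

Going by these compounds, it remains open whether the same replacement would also leave compound 1 and compound 3 within the scatter of their boron-bearing forms. On these data alone, it is also open whether a carboxylic acid, an amine or a longer chain on this chain carbon would move the number beyond the scatter.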